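The compounds below may be only part of what the source reports. "The series", "measured", "known", "first", "only" and "open" are said of these compounds alone.

Measured so far in a functional assay on A2780 cells (Homo sapiens) for inhibition, with a stated time of 72 h, tested at 10 uM; on this read-out lower numbers stand for less inhibition of growth and higher numbers for more inhibition of growth at the one concentration tested:
Compound 1 `CC1(C)CCOc2ccc(NC(=O)Nc3ccc([N+](=O)[O-])cc3)cc21`: 74%
Compound 2 `CCC1(CC)CC(CC)(CC)c2cc(NC(=O)Nc3ccc(C(F)(F)F)cc3)ccc2O1`: 86.2%
Compound 3 `CC1(C)CC(C)(C)c2cc(NC(=O)Nc3ccc(C#N)cc3)ccc2O1`: 93%

Compound 2 stands second highest of the three numbers in this assay. Its nearest neighbour is compound 3, whose value lies within the usual scatter of that of compound 2, so no order can be read between the two. Compound 1 lies furthest from compound 2, and that gap is beyond the scatter.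

Compound 4 `CCC1(CC)CC(CC)(CC)c2cc(NC(=O)Nc3ccc(OC(F)(F)F)cc3)ccc2O1` is not yet measured. It differs from compound 2 in one place: trifluoromethoxy in place of trifluoromethyl on an aromatic carbon. No step of this kind has been measured in the series, so nothing shown here sets its size or direction. The change is small, and the expected step is a number 2.2 percentage points lower from compound 2 to compound 4 (within the scatter), that is, none beyond the scatter. Compound 4 is estimated at 84%, with a range from 70% to 95%.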

Compound 4, percent growth inhibition at one concentration: 67%
Beside the measured number, compound 4's estimate is 17 percentage points above it, outside the stated range (below it).
By their numbers in this assay, from the lowest: compounds 4 and 1 (each within the scatter of the next); then compounds 2 and 3 (each within the scatter of the next).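

In this assay the series gains its first one-place step, a number 19.2 percentage points lower from compound 2 to compound 4 (beyond the scatter), so at this aromatic carbon, para to a large group, the exchange of trifluoromethyl for trifluoromethoxy is not a silent one. The change enters one oxygen, and the step lies beyond the scatter. Nothing at hand accounts for this step.

Open, going by these compounds, is whether the same exchange gives a step of similar size on the core of compound 1 or compound 3. Also open, on these data alone, is how an amine or a carboxylic acid would read at this carbon.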